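The source may report more compounds than this note shows. Statements on the series, on what has been measured and on what is new or still open speak of the compounds shown alone.

Measured in a functional assay on OVCAR-3 cells (Homo sapiens) for inhibition, read by sulforhodamine B assay, with a stated time of 48 h; on this read-out lower numbers stand for stronger inhibition of growth and higher numbers for weaker inhibition of growth:

- compound 1 `CCOC(=O)c1nn(-c2ccccc2)c(-c2ccc([N+](=O)[O-])cc2)c1CNC(C)(C)C`: 8780 nM; 288000 nM (2 entries)
- compound 2 `Cc1ccc(-c2c(CNC(C)(C)C)c(C(=O)O)nn2-c2ccccc2)cc1`: 283000 nM

In this assay, compound 2 has a single number, 283000 nM, and one further entry that gives no single number. Its position therefore rests on one reading. Compound 1 has two entries that lie far apart: the several entries of compound 1 in this assay, 8780 nM; 288000 nM (2 entries).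

The next compound is compound 3 `CC(C)(C)NCc1c(C(=O)O)nn(-c2ccccc2)c1-c1ccc([N+](=O)[O-])cc1`, not yet measured. It differs from compound 2 by nitro in place of methyl on an aromatic carbon, para to a large group, so 4-methylphenyl becomes 4-nitrophenyl. Going by the values given here, the series offers no measured step between compounds that differ in one place, so the size of this change has no direct precedent here.

No shift beyond the scatter is expected in this assay, and no direction is favoured with any confidence. The estimated step is a 1.4-fold lower number from compound 2 to compound 3 (0.15 log units; within the scatter). This expectation is anchored on compound 2 at 283000 nM, and the range is kept wide because the several entries of compound 1 in this assay, 8780 nM; 288000 nM (2 entries) shows how far entries can spread. For compound 3 the expected value is 200000 nM, with an estimated range of 40000 nM to 450000 nM.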

Compound 3, concentration for 50% growth inhibition: > 634000 nM
Compound 3 gave a limit, no number; the forecaster's own chance of this, stated with the estimate: 25%; at least 3.1-fold (0.50 log units) between middle value and limit.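

In this assay, the series now has its first measured step between compounds that differ in one place: an at least 2.2-fold higher number from compound 2 to compound 3 (0.35 log units; beyond the scatter), with nitro in place of methyl on an aromatic carbon, para to a large group. Compound 3 gives > 634000 nM, which is a limit of the assay and not a number. Among these carboxylic acids, 4-nitrophenyl therefore brings no gain in growth inhibition over 4-methylphenyl, although the size of the step rests on one reading for compound 2 and entries can lie far apart: the several entries of compound 1 in this assay, 8780 nM; 288000 nM (2 entries)

The compounds shown leave open how a methoxy group or a chlorine on that same aromatic carbon would read in this assay, so the step gives one comparison and no trend across groups at this place. An ethyl ester carrying 4-methylphenyl is also absent from the compounds shown, so it stays open whether nitro in place of methyl would read the same way outside the carboxylic acids.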